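The source may report more compounds than this note shows. Statements on the series, on what has been measured and on what is new or still open speak of the compounds shown alone.

Measured compounds in the series:

Compound 1, `O=C[C@H](C[C@@H]1CCNC1=O)NC(=O)[C@H](CC1CCCCC1)NC(=O)c1cc2ccccc2[nH]1`. In a toxicity assay on Huh-7 cells (Homo sapiens) for cytotoxicity (a lower number here means that less compound is tolerated, a higher number that more compound is tolerated), compound 1 gives > 100000 nM, a limit of the assay.
Compound 2, `CCCC1CCC(OC(=O)N[C@@H](CC(C)C)C(=O)N[C@H](C=O)C[C@@H]2CCNC2=O)CC1`. In this assay compound 2 gives > 100000 nM, a limit of the assay.
Compound 3, `CC(C)C[C@H](NC(=O)OCC1CCC(F)(F)CC1)C(=O)N[C@H](C=O)C[C@@H]1CCNC1=O`. In this assay compound 3 gives > 100000 nM, a limit of the assay.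

Compound 2 therefore stands only at a limit in this assay, and the same holds for every value shown: the limit of > 100000 nM in this assay, at which 3 of the 3 values shown sit. Among the compounds with values here, the one step measured at the carbamate oxygen, a step that the two limits leave unreadable from compound 2 to compound 3, is unreadable, since both ends sit at the limit.

Compound 4, `CC(C)C[C@H](NC(=O)OC1CCCCC1)C(=O)N[C@H](C=O)C[C@@H]1CCNC1=O`, differs from compound 2 by hydrogen in place of propyl on a saturated ring carbon. Within the data shown here, no measured step speaks to this change; the step from compound 2 to compound 3 is the only one at the same part of the molecule and its size cannot be read. With all three values at the limit, the expectation for compound 4 is a value again at or past the limit, the step that the limit leaves unreadable from compound 2 to compound 4 expected to be none beyond the scatter. For compound 4 the estimate is 150000 nM, within 60000 nM to 400000 nM.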

Compound 4, half-maximal cytotoxic concentration: > 100000 nM
Compound 4 gave a limit, no number; the forecaster's own chance of this, stated with the estimate: 85%; the middle value is on the limit's open side.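

Compound 4 stands at a limit of the assay, as do compound 2 and compound 3, so no step among these three can be read in this assay. The compounds shown leave open whether any group on the carbamate oxygen gives a measurable value, as all sit at one limit: the limit of > 100000 nM in this assay, at which 4 of the 4 values shown sit.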